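Swapping Dichloro for Dimethoxy on a Benzyl Side Chain

A few compounds are considered here, and "the series" means these few. Any claim that something is new, unique, unknown or untested is made for them only; others in the source may bear on it.

Of the compounds shown here, three built on one shared core have been tested in a functional assay on MDA-MB-435 cells (Homo sapiens) for inhibition, read by sulforhodamine B assay, with a stated time of 48 h; a lower number here means a stronger inhibitor of growth, a higher number a weaker inhibitor of growth. Compound 1 `Nc1cc(N)c2nc(-c3ccccc3)c(Oc3ccc(Cl)c(Cl)c3)nc2c1` gives 20900 nM. Compound 3 `Nc1cc(N)c2nc(-c3ccccc3)c(NCc3ccc(Cl)c(Cl)c3)nc2c1` gives 7590 nM, the lower of the two numbers, and its gap to compound 1 lies beyond the usual scatter. For compound 2 `CCOC(=O)[C@H](CCC(=O)O)NC(=O)c1ccc(CNc2nc3cc(N)cc(N)c3nc2-c2ccccc2)cc1` the assay reports a limit rather than a number, < 100000 nM, which is true of one of the three values (the limit of < 100000 nM in this assay, at which 1 of the 3 values shown sits). Compound 4 `COc1ccc(CNc2nc3cc(N)cc(N)c3nc2-c2ccccc2)cc1OC` has not yet been measured; it differs from compound 3 by 3,4-dimethoxyphenyl in place of 3,4-dichlorophenyl on a saturated chain carbon bound to a nitrogen on an aromatic ring. For the measured compounds named here, no measured pair shows such a swap, so the step expected from compound 3 to compound 4 is a 2.6-fold higher number from compound 3 to compound 4 (0.42 log units; beyond the scatter), a modest weakening that may not clear the scatter. Compound 4 is therefore estimated at 20000 nM, with a likely range from 6000 nM to 70000 nM.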

Compound 4, concentration for total growth inhibition: 4070 nM
Compound 4: middle estimate off by 4.9-fold (0.69 log units), on the high side; the measured number lies below the stated range.
By their numbers in this assay, from the lowest: compounds 4 and 3 (each within the scatter of the next); then compound 1.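

In this assay, 3,4-dimethoxyphenyl in place of 3,4-dichlorophenyl on a saturated chain carbon bound to a nitrogen on an aromatic ring gives a 1.9-fold lower number from compound 3 to compound 4 (0.27 log units; within the scatter). For the compounds shown here, this is the first direct comparison at this position, and it separates the two groups by no more than repeat measurements would, even though only the entering group has hydrogen-bond acceptors. Nothing measured here offers a reason for this result. Still open, going by these compounds, is whether a carboxylic acid or an amine in place of these groups, or a longer chain at this position, would shift the number beyond the scatter.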